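Removing one methoxy from compound 3: expected effect

This account rests on a few compounds, and the source may have more. Where it says the series, first, only, none or still open, it means among the compounds named here.

Measured in a functional assay on A549 cells (Homo sapiens) for antiproliferative activity, read by MTT assay, with a stated time of 48 h; on this read-out higher numbers stand for weaker inhibition and lower numbers for stronger inhibition:
Compound 1 `COc1cc(/C=N/c2c(C#N)ncn2-c2ccc(F)cc2)cc(OC)c1OC`: 9880 nM
Compound 2 `N#Cc1ncn(-c2ccc(F)cc2)c1/N=C/c1ccc(O)cc1`: 16300 nM
Compound 3 `COc1cc(/C=N/c2c(C#N)ncn2Cc2ccc(F)cc2)cc(OC)c1OC`: 9710 nM

Compound 3 lies within the scatter of both other compounds, so no order can be read among these values. The next structure is compound 4 `COc1ccc(/C=N/c2c(C#N)ncn2Cc2ccc(F)cc2)cc1OC`, with hydrogen in place of methoxy on an aromatic carbon. Among the compounds with values here, the only measured single-place step is a 1.0-fold lower number from compound 1 to compound 3 (0.01 log units; within the scatter). That step concerns the group on the aromatic nitrogen, so it bears only indirectly on the methoxy change. Within the data shown here, no measured step removes a single methoxy. The ring carrying the methoxy groups in compound 3 is substituted differently in compound 2 16300 nM, and that value remains within the scatter of compound 3. As far as these compounds go, on that evidence, no step beyond the scatter is expected in this assay, and the direction stays open. The estimated step is a 1.2-fold higher number from compound 3 to compound 4 (0.07 log units; within the scatter). For compound 4 the expected value is 11500 nM, with an estimated range of 5500 nM to 24000 nM.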

Compound 4, half-maximal inhibitory concentration: 9130 nM
Compound 4: the middle estimate sits 1.3-fold (0.10 log units) above what was measured, and the stated range covers the measured number.
By their numbers in this assay, from the lowest: compounds 4, 3, 1 and 2 (each within the scatter of the next).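

Hydrogen in place of methoxy on this aromatic carbon, ortho to a methoxy group and meta to a large group, gives a 1.1-fold lower number from compound 3 to compound 4 (0.03 log units; within the scatter) in this assay. Within the data shown here, this is the first single-place step on the ring carrying the methoxy groups, as the earlier step concerned only the group on the aromatic nitrogen. At this position, the methoxy can give way to hydrogen without a step beyond the scatter, and nothing at hand explains this result.

As far as these compounds go, whether an amine or a carboxylic acid in place of this methoxy would give a step beyond the scatter remains open. Also open, from the compounds shown here alone, is whether the same hydrogen-for-methoxy change would again stay within the scatter with 4-fluorophenyl on the aromatic nitrogen.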